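This account rests on a few compounds, and the source may have more. Where it says the series, first, only, none or still open, it means among the compounds named here.

Measured compounds:
compound 1 `O=C(O)/C=C/c1ccc(/C(=C(/CCF)c2ccccc2)c2ccc3[nH]ncc3c2)cc1` — 2.1 nM
compound 2 `CC(C)/C(=C(/c1ccc(/C=C/C(=O)O)cc1)c1ccc2[nH]ncc2c1)c1ccccc1` — 4 nM

In a functional assay on MCF7 cells (Homo sapiens) for cytotoxicity, read by CellTiter-Glo, with a stated time of 5 days (a higher number here means a weaker inhibitor, a lower number a stronger inhibitor), compound 2 gives the higher of the two numbers, its nearest neighbour being compound 1, though the pair lie within the scatter. Going by the values given here, the one step that bears on the new case is a 1.9-fold higher number from compound 1 to compound 2 (0.28 log units; within the scatter), a swap of one small alkyl chain for another at the same position. Compound 3 `O=C(O)/C=C/c1ccc(/C(=C(\c2ccccc2)C2CCC2)c2ccc3[nH]ncc3c2)cc1` differs from compound 2 by cyclobutyl in place of isopropyl on a double-bonded chain carbon bound to an aromatic carbon and a double-bonded chain carbon. Since the earlier alkyl swap moved the number little, the expected step of a 1.1-fold higher number from compound 2 to compound 3 (0.05 log units; within the scatter) is small, without clear direction. Compound 3 is therefore estimated at 4.5 nM, within 1.5 nM to 14 nM.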

Compound 3, half-maximal inhibitory concentration: 1.4 nM
Compound 3: the middle estimate sits 3.2-fold (0.51 log units) above what was measured, and the stated range ends above it.
By their numbers in this assay, from the lowest: compounds 3, 1 and 2 (each within the scatter of the next, the first and the last beyond it).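

In this assay, the place on a double-bonded chain carbon bound to an aromatic carbon and a double-bonded chain carbon now shows a step beyond the scatter: cyclobutyl in place of isopropyl gives a 2.9-fold lower number from compound 2 to compound 3 (0.46 log units; beyond the scatter). Cyclobutyl in place of 2-fluoroethyl gives only a 1.5-fold lower number from compound 1 to compound 3 (0.18 log units; within the scatter), so the ring stands apart from isopropyl but not from 2-fluoroethyl. The data offer no measurement that would explain this difference. The compounds shown leave open whether cyclopentyl, or a chain ending in an amine, would fit at this place.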